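The source may report more compounds than this note shows. Statements on the series, on what has been measured and on what is new or still open speak of the compounds shown alone.

Working notes on the series. Within the data shown here, in a physicochemical assay, read by spectrophotometry, with a stated time of 30 min (a higher number here means a weaker inhibitor, a lower number a stronger inhibitor), compound 2 `COc1cc(/C=N/NC(=O)CCCc2nc3ccccc3c(=O)[nH]2)ccc1O` gives 236000000 nM, the highest of the three numbers so far. Compound 3 `COc1cc(/C=N/NC(=O)CCCc2nc3ccccc3c(=O)[nH]2)cc(OC)c1O` gives 97000000 nM and compound 1 `O=C(CCCc1nc2ccccc2c(=O)[nH]1)N/N=C/c1cc(O)c(O)c(O)c1` gives 78000000 nM.

The next comparison is with compound 4 `O=C(CCCc1nc2ccccc2c(=O)[nH]1)N/N=C/c1ccc([N+](=O)[O-])cc1`, where 4-nitrophenyl stands in place of 4-hydroxy-3-methoxyphenyl on a carbon with a double bond to nitrogen: 4-nitrophenyl in place of 4-hydroxy-3-methoxyphenyl on a carbon with a double bond to nitrogen.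

Among the measured compounds shown here, two measured steps bear on this, both at the same aryl group and both modest: a 3.0-fold higher number from compound 1 to compound 2 (0.48 log units; beyond the scatter) and a 2.4-fold lower number from compound 2 to compound 3 (0.39 log units; beyond the scatter). Fewer hydroxy groups accompany the higher number in a 3.0-fold higher number from compound 1 to compound 2 (0.48 log units; beyond the scatter), while the hydroxy count stays the same in a 2.4-fold lower number from compound 2 to compound 3 (0.39 log units; beyond the scatter), so the hint of a pattern is thin. For the measured compounds named here, no measured compound carries a nitro group, and all three keep at least one hydroxy group. A modest move to a higher number is therefore expected, of about the same size as these steps or smaller, and the estimated step is a 1.3-fold higher number from compound 2 to compound 4 (0.10 log units; within the scatter). For compound 4 the expected value is 300000000 nM, with an estimated range of 120000000 nM to 700000000 nM.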

Compound 4, half-maximal inhibitory concentration: 316000000 nM
Beside the measured number, compound 4's estimate is 1.1-fold (0.02 log units) below it, and the stated range covers the measured number.
By their numbers in this assay, from the lowest: compounds 1 and 3 (each within the scatter of the next); then compounds 2 and 4 (each within the scatter of the next).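

In this assay, 4-nitrophenyl in place of 4-hydroxy-3-methoxyphenyl on the carbon with a double bond to nitrogen gives a 1.3-fold higher number from compound 2 to compound 4 (0.13 log units; within the scatter) and so stays within the scatter, which shows that this position tolerates an aryl group with no hydroxy group and no hydrogen-bond donors without a clear shift from compound 2. The same group in place of 3,4,5-trihydroxyphenyl gives a 4.1-fold higher number from compound 1 to compound 4 (0.61 log units; beyond the scatter) and thus stays clearly apart from the trihydroxy compound. No measurement available here accounts for either step.

Still open, going by these compounds, is how unsubstituted phenyl, or an aryl group bearing an amine or a carboxylic acid, would read in this assay at this position. Also open, on these data alone, is whether a longer chain on the shared core would change these steps.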